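Shifting a methyl group on the amide-bound ring

A few compounds are considered here, and "the series" means these few. Any claim that something is new, unique, unknown or untested is made for them only; others in the source may bear on it.

Going by the values given here, compound 2 `COc1ccc(-n2nc(C(=O)Nc3ccc(C)cc3)nc2-c2cc(OC)c(OC)c(OC)c2)cc1` gives 58% in a functional assay on the whole organism for inhibition, with Rattus norvegicus as the target, read by paw edema, with stated times of 30 min and 4 h, at a dose of 0.28 mmol/kg by the oral route (on this read-out higher numbers stand for more inhibition at the one dose given (going by the name of the read-out) and lower numbers for less inhibition), the higher of the two numbers measured so far; its nearest neighbour, compound 1 `COc1ccc(-n2nc(C(=O)Nc3ccccc3OC)nc2-c2cc(OC)c(OC)c(OC)c2)cc1`, gives 24%. Compound 3 `COc1ccc(-n2nc(C(=O)Nc3ccccc3C)nc2-c2cc(OC)c(OC)c(OC)c2)cc1` differs from compound 2 only by 2-methylphenyl in place of 4-methylphenyl on an amide-type nitrogen. Among the compounds with values here, the single measured step, a number 34 percentage points higher from compound 1 to compound 2 (beyond the scatter), bears on this only loosely, since it swaps a 2-methoxyphenyl for a 4-methylphenyl rather than one methylphenyl for another. With the lone 2-substituted analogue, compound 1, at the low end, a moderate fall is expected for compound 3, namely a number 20 percentage points lower from compound 2 to compound 3 (beyond the scatter), giving an estimated 38% with a range from 15% to 60%.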

Compound 3, a percentage reported as inhibition, in the whole organism at one dose (the size of the read-out at that dose, not a potency): 46%
For compound 3 the middle estimate is 8 percentage points below the measured one; low and high end bracket the measured number.
By their numbers in this assay, from the lowest: compound 1; then compound 3; then compound 2.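

Moving the methyl on the ring attached to the amide-type nitrogen, with the atoms unchanged, gives in this assay a number 12 percentage points lower from compound 2 to compound 3 (beyond the scatter) and so shows that its place on the ring matters. With the substituent's place held, methyl in place of methoxy gives a number 22 percentage points higher from compound 1 to compound 3 (beyond the scatter) and so shows that the identity of the group matters too. Nothing measured here explains either step.

From the compounds shown here alone, it remains open how a larger group on the same ring, such as 4-ethylphenyl or 4-chlorophenyl, would compare with 4-methylphenyl. Going by these compounds, the effect of a ring carrying an amine or a carboxylic acid also remains open.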